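Replacing the Benzimidazolylmethyl Thioether with a Bromobenzyl Thioether

A few compounds are considered here, and "the series" means these few. Any claim that something is new, unique, unknown or untested is made for them only; others in the source may bear on it.

Of the compounds shown here, two have so far been measured in a functional assay on MCF7 cells (Homo sapiens) for inhibition, read by MTT assay, with a stated time of 72 h; a higher number here means a weaker inhibitor, a lower number a stronger inhibitor. Compound 1 `CCCCCc1c(C)nc2nc(SCc3ccc(Cl)cc3)nn2c1Nc1cc(-c2ccccc2)[nH]n1` gives 6390 nM. Compound 2 `Cc1cc(Nc2cc(-c3ccccc3)[nH]n2)n2nc(SCc3nc4ccccc4[nH]3)nc2n1` gives 2730 nM, which is the lowest of the two numbers; compound 1 sits above it by a gap that lies beyond the usual scatter. Compound 3 `Cc1cc(Nc2cc(-c3ccccc3)[nH]n2)n2nc(SCc3ccc(Br)cc3)nc2n1` has not yet been measured. It arises from compound 2 by a single change at the sulfur-bound chain carbon: 4-bromophenyl in place of 1H-benzimidazol-2-yl on a saturated chain carbon bound to a sulfur. Going by the values given here, compound 1 differs from compound 2 in more than one place, so no measured pair isolates this particular exchange, and the direction of its effect cannot be read from the numbers at hand. Among the compounds with values here, with only two measured compounds and no matched step, the estimate for compound 3 rests mainly on the spread of the two values already seen. A step from compound 2 to compound 3 of a 1.6-fold higher number from compound 2 to compound 3 (0.22 log units; within the scatter) is expected, a modest move toward a weaker inhibitor that may still fall within the scatter. Compound 3 is therefore estimated at 4500 nM, within a range from 1500 nM to 14000 nM.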

Compound 3, half-maximal inhibitory concentration: 2720 nM
The estimate for compound 3 lay 1.7-fold (0.22 log units) above the measured number, and the stated range covers the measured number.
By their numbers in this assay, from the lowest: compounds 3 and 2 (each within the scatter of the next); then compound 1.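

In this assay, going by these compounds alone, the first matched step at this position, 4-bromophenyl in place of 1H-benzimidazol-2-yl on a saturated chain carbon bound to a sulfur gives a 1.0-fold lower number from compound 2 to compound 3 (0.00 log units; within the scatter) and so leaves the two compounds indistinguishable. The group that leaves holds a five-membered aromatic ring with 2 hetero atoms, a hydrogen-bond donor and a hydrogen-bond acceptor, while the group that enters has none of these, so in this one pair the read-out does not depend on keeping them. No measurement at hand accounts for the two groups reading alike.

The compounds shown leave open whether this match extends to other groups at the same place, such as an unsubstituted phenyl, a 4-methoxyphenyl, a pyridin-2-yl or a phenyl bearing a carboxylic acid or an amine. They also leave the part played by the pentyl chain of compound 1 unresolved, since compound 1 differs from compound 2 and from compound 3 in more than one place.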